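This account rests on a few compounds, and the source may have more. Where it says the series, first, only, none or still open, it means among the compounds named here.

Working notes on the series. Going by the values given here, the series so far comprises two measured compounds. Compound 1 `CNc1nc2c(-c3ccnc(OC)c3)cnn2cc1OC` gives 310 nM in an assay on isolated protein for inhibition of activin receptor type-2A (Homo sapiens), read by 33P incorporation, with a stated time of 20 min, in the presence of a further agent that is not named here; on this read-out lower numbers stand for stronger inhibition and higher numbers for weaker inhibition. Among the compounds with values here, compound 2 `CCc1nc2c(-c3ccnc(OC)c3)cnn2cc1OC` gives 960 nM in this assay; the single step, a 3.1-fold higher number from compound 1 to compound 2 (0.49 log units; beyond the scatter), places compound 2 at the higher of the two numbers, with compound 1 as the only neighbour.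

Compound 3 `COc1cc(-c2cnn3cc(OC)c(-c4cc(C)no4)nc23)ccn1` differs from compound 2 by 3-methyl-1,2-oxazol-5-yl in place of ethyl on an aromatic carbon. Within the data shown here, no measured step exchanges a chain for a ring at this carbon; the only step available, a 3.1-fold higher number from compound 1 to compound 2 (0.49 log units; beyond the scatter), shows that this position moves the number by a modest amount between methylamino and ethyl, and nothing more. The entering group carries two acceptors, as did methylamino in part, so the step of a 1.9-fold lower number from compound 2 to compound 3 (0.28 log units; within the scatter) is expected to be small and is assigned a wide range. Compound 3 is estimated at 500 nM in this assay, between 100 nM and 3000 nM.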

Compound 3, half-maximal inhibitory concentration: 3000 nM
Beside the measured number, compound 3's estimate is 6.0-fold (0.78 log units) below it, and the stated range covers the measured number.
By their numbers in this assay, from the lowest: compound 1; then compound 2; then compound 3.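

Exchanging ethyl for 3-methyl-1,2-oxazol-5-yl on this aromatic carbon gives a 3.1-fold higher number from compound 2 to compound 3 (0.49 log units; beyond the scatter) in this assay and so shows that an aromatic ring here, with the two hydrogen-bond acceptors counted on it, brings no gain over the plain chain. Against methylamino the same group gives a 9.7-fold higher number from compound 1 to compound 3 (0.99 log units; beyond the scatter) and is the largest step in the series, so the position spans more than the first pair suggested, with methylamino lowest, ethyl in the middle and the ring highest in this set of three. Nothing available bears on the reason for these rises.

Still open, from the compounds shown here alone, is whether the methyl on the ring contributes to the higher number, which the unsubstituted 1,2-oxazol-5-yl would test. Also open, going by these compounds, is whether another amine at this carbon, such as ethylamino or morpholine, stays near compound 1 or goes beyond it.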